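The compounds below may be only part of what the source reports. "The series", "measured", "known", "first", "only" and "open" are said of these compounds alone.

For the measured compounds named here, compound 1 `CN1CCN(CC(=O)Nc2nc3ccccc3[nH]2)CC1` gives 61.6% in a functional assay, read by spectrophotometry, with a stated time of 30 min, tested at 200 ug/mL (on this read-out higher numbers stand for a stronger effect at the one concentration tested and lower numbers for a weaker effect), the lowest of the two numbers measured so far. Compound 2 `O=C(CN1CCN(c2ccccn2)CC1)Nc1nc2ccccc2[nH]1` gives 76.2% in this assay. Going by the values given here, the single measured step, a number 14.6 percentage points higher from compound 1 to compound 2 (beyond the scatter), bears on the move to compound 3 `O=C(CN1CCN(c2ccc([N+](=O)[O-])cc2)CC1)Nc1nc2ccccc2[nH]1`, which carries 4-nitrophenyl in place of methyl on an amine nitrogen in a ring. Both changes put a six-membered aromatic ring in place of methyl on an amine nitrogen in a ring, so a modest rise of similar size is expected, the estimated step being a number 10.4 percentage points higher from compound 1 to compound 3 (beyond the scatter). Compound 3 is therefore expected to give 72%, in a range from 58% to 86%.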

Compound 3, a percentage reported as activity, at one concentration (the size of the read-out at that concentration, not a potency): 76.7%
Estimate against measurement, compound 3: 4.7 percentage points below; low and high end bracket the measured number.
By their numbers in this assay, from the lowest: compound 1; then compounds 2 and 3 (each within the scatter of the next).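

Pyridin-2-yl is no longer the only large group on this amine nitrogen that goes with a rise in this assay, since 4-nitrophenyl in place of methyl gives a number 15.1 percentage points higher from compound 1 to compound 3 (beyond the scatter) at the same position. The exchange of pyridin-2-yl for 4-nitrophenyl gives a number 0.5 percentage points higher from compound 2 to compound 3 (within the scatter) and so leaves compound 2 and compound 3 indistinguishable on this read-out. Nothing available explains either step. Open, on these data alone, is whether unsubstituted phenyl or a benzyl group on this nitrogen would fall with compound 2 and compound 3. Also open, as far as these compounds go, is where a saturated ring such as cyclohexyl would fall.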